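The compounds below may be only part of what the source reports. "The series", "measured", "known", "first", "only" and "open" are said of these compounds alone.

In a functional assay on FaDu cells (Homo sapiens) for cytotoxicity, read by MTT assay, with a stated time of 72 h (a lower number here means that less compound is tolerated, a higher number that more compound is tolerated), compound 1 `COCCn1cc(C(=O)C(=O)Nc2ccc(OCC(=O)O)nc2)c2ccccc21` gives > 10000 nM, which is a limit and not a number. Compound 2 `COc1ccc(NC(=O)C(=O)c2cn(C(C)C)c3ccc(Cl)cc23)cn1` gives > 10000 nM, also a limit. Compound 3 `COc1nc(NC(=O)C(=O)c2cn(C(C)C)c3ccccc23)ns1` gives > 10000 nM, again a limit. Compound 1 thus stands with the whole set at the limit of > 10000 nM in this assay, at which 3 of the 3 values shown sit, and no number fixes its place. Compound 4 `COCCn1cc(C(=O)C(=O)Nc2ccc(OC(C)C)nc2)c2ccccc21` keeps the core of compound 1 but carries isopropyl in place of carboxymethyl on an oxygen on an aromatic ring. Going by the values given here, no measured step guides this change. A shift toward lower numbers in this assay is expected, of uncertain size, and the result may stay at the limit. The expected step is an at least 2.0-fold lower number from compound 1 to compound 4 (0.30 log units; that floor lies within the scatter). Compound 4 is estimated at 5000 nM, within an expected range of 200 nM to 20000 nM.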

Compound 4, concentration lethal to 50% of the cells in the FaDu assay: 55 nM
Compound 4: middle estimate off by 91-fold (1.96 log units), on the high side; the whole stated range lies above it.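

In the FaDu assay, isopropyl in place of carboxymethyl on this oxygen gives an at least 180-fold lower number from compound 1 to compound 4 (2.25 log units; beyond the scatter), so this is the first change shown that brings a value off the limit, and this one place can move the read-out strongly. In a physicochemical assay for solubility, in phosphate buffer, at pH 7.4 (on this read-out higher numbers stand for higher solubility and lower numbers for lower solubility), compound 1 gives <= 200000 nM, which is a limit. In the physicochemical assay compound 4 gives 10000 nM, and the step between the two cannot be read. This single pair leaves open whether losing carboxymethyl or gaining isopropyl carries the step, and how an aminoethyl group or a longer alkyl chain on this oxygen would read.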